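Shifting Dimethoxyphenyl Substitution on a Saturated Ring Carbon

The source may hold more compounds than are shown below. What is called first, only, known or untested is meant among the compounds shown, and "the series" means these compounds.

Compound 1, `COc1cc(C2=NN(C(C)=O)C(c3ccc(F)cc3)O2)cc(OC)c1OC`: 0.1%
Compound 2, `COc1cc(C2=NN(C(C)=O)C(c3ccccc3F)O2)cc(OC)c1OC`: 31.6%
Compound 3, `COc1cc(C2=NN(C(C)=O)C(c3cccc(OC)c3OC)O2)cc(OC)c1OC`: 58.2%

In a functional assay on PC-3 cells (Homo sapiens) for antiproliferative activity, read by MTT assay, tested at 5 uM (a lower number here means a weaker effect, a higher number a stronger effect of the compound at the concentration tested), compound 3 stands highest of the three measured numbers. Its nearest neighbour is compound 2, reached by a number 26.6 percentage points higher from compound 2 to compound 3 (beyond the scatter), and the furthest is compound 1, reached by a number 58.1 percentage points higher from compound 1 to compound 3 (beyond the scatter). Between the two fluorophenyl analogues the step was a number 31.5 percentage points higher from compound 1 to compound 2 (beyond the scatter).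

Compound 4, `COc1ccc(OC)c(C2OC(c3cc(OC)c(OC)c(OC)c3)=NN2C(C)=O)c1`, differs from compound 3 in one place: 2,5-dimethoxyphenyl in place of 2,3-dimethoxyphenyl on a saturated ring carbon. Every measured step here swaps the aryl group on that same saturated ring carbon, and each was beyond the scatter, so the group at this position clearly matters. Among the measured compounds shown here, no measured pair, however, keeps two methoxy groups and merely rearranges them; the nearest precedent, the change from compound 2 to compound 3, added a methoxy pair in place of a fluorine. With both dimethoxyphenyl groups counting the same atoms and acceptors, the account expects the step of a number 13.2 percentage points lower from compound 3 to compound 4 (beyond the scatter) to be modest, likely downward, and possibly within the scatter. Compound 4 is therefore estimated at 45%, with a range from 20% to 70%.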

Compound 4, a percentage reported as inhibition, at one concentration (the size of the read-out at that concentration, not a potency): 43.2%
Beside the measured number, compound 4's estimate is 1.8 percentage points above it; low and high end bracket the measured number.
By their numbers in this assay, from the lowest: compound 1; then compound 2; then compound 4; then compound 3.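

In this assay, rearranging the two methoxy groups alone changes the read-out, giving a number 15 percentage points lower from compound 3 to compound 4 (beyond the scatter), even though the leaving and entering groups have the same atoms and the same counted hydrogen-bond acceptors, so these counts alone do not fix the result at this saturated ring carbon. The 2,5-dimethoxyphenyl group also stands above both fluorophenyl groups, with a number 11.6 percentage points higher from compound 2 to compound 4 (beyond the scatter) and a number 43.1 percentage points higher from compound 1 to compound 4 (beyond the scatter), so both dimethoxyphenyl compounds rank above both fluorophenyl compounds among these four. Nothing available here accounts for the effect of the methoxy arrangement.

On these data alone, whether any other arrangement of the two methoxy groups would exceed compound 3 remains open, as does the outcome of placing a hydroxyl or dimethylamino group on this aryl ring. The compounds also share the acetyl group throughout, leaving open what a longer acyl chain would do.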